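The compounds below may be only part of what the source reports. "The series", "measured", "known", "first", "only" and "open" are said of these compounds alone.

Measured compounds:
compound 1 `C[C@@H](NC(=O)Nc1cccc(C(F)(F)F)c1)c1ccccc1` with 82%
compound 2 `C[C@@H](NC(=O)Nc1cc(F)ccc1F)c1ccccc1` with 100%

In an ADME assay on the whole organism with Oryza sativa as the target, tested at 0.1 uM (a lower number here means a stronger effect, a higher number a weaker effect of the compound at the concentration tested), compound 2 gives 100%, the highest of the two numbers, with compound 1 at 82%, a gap beyond the usual scatter. Compound 3 `C[C@@H](NC(=O)Nc1cc(C(F)(F)F)ccc1F)c1ccccc1` has not yet been measured. It differs from compound 2 in one place: trifluoromethyl in place of fluoro on an aromatic carbon. Among the compounds with values here, no pair of measured compounds that differ in a single place exists here, so no measured step can guide the estimate directly. Compound 1, which also carries a trifluoromethyl group, sits lower than compound 2, which suggests that compound 3 may fall somewhat below compound 2 as well. The step from compound 2 to compound 3 is expected to be a modest decrease, a number 12 percentage points lower from compound 2 to compound 3 (beyond the scatter), in this assay. Compound 3 is estimated to give 88%, within a range from 70% to 100%.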

Compound 3, a percentage reported as activity, at one concentration (the size of the read-out at that concentration, not a potency): 87%
Estimate against measurement, compound 3: 1 percentage points above; the range from low to high includes it.
By their numbers in this assay, from the lowest: compounds 1 and 3 (each within the scatter of the next); then compound 2.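

In this assay trifluoromethyl in place of fluoro, on an aromatic carbon para to a fluoro group, gives a number 13 percentage points lower from compound 2 to compound 3 (beyond the scatter) and so provides the first measured sign that this change at this position moves the number beyond the scatter. Fluoro in place of hydrogen on an aromatic carbon gives a number 5 percentage points higher from compound 1 to compound 3 (within the scatter) and so leaves the trifluoromethyl compounds within the scatter of each other. Nothing available here explains either step.

The compounds shown leave open how a chloro, methyl or methoxy group, or an amine or a carboxylic acid, would read at the same aromatic carbon. They also leave open whether the same trifluoromethyl step would hold in the absence of the fluoro group or with a longer chain on the shared core.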